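A few compounds are considered here, and "the series" means these few. Any claim that something is new, unique, unknown or untested is made for them only; others in the source may bear on it.

Working notes on the series. Compound 2, `O=C(CN1CCC(c2cccc[n+]2[O-])CC1)Nc1cccc(F)c1`, in a functional assay on HEK293 cells for agonist activity at D(4) dopamine receptor (Homo sapiens), read by FLIPR (a lower number here means that less compound is needed, a higher number that more compound is needed for the effect), gives 160 nM. Compound 1, `CCc1cccc(NC(=O)CN2CCC(c3cccc[n+]3[O-])CC2)c1`, in this assay gives 95 nM; the step of a 1.7-fold higher number from compound 1 to compound 2 (0.23 log units; within the scatter) is the only one measured so far. Compound 3, `Cc1cc(NC(=O)CN2CCC(c3cccc[n+]3[O-])CC2)ccc1F`, is not yet measured; it carries 4-fluoro-3-methylphenyl in place of 3-fluorophenyl on an amide-type nitrogen. The step from compound 1 to compound 2 also changes only a group on that aromatic ring, and it stayed within the scatter, so no step beyond the scatter is expected in this assay here either. For compound 3 the estimate in this assay is 150 nM, range 60 nM to 400 nM, meaning an expected step of a 1.1-fold lower number from compound 2 to compound 3 (0.03 log units; within the scatter).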

Compound 3, half-maximal effective concentration: 18 nM
The estimate for compound 3 lay 8.3-fold (0.92 log units) above the measured number, and the stated range ends above it.
By their numbers in this assay, from the lowest: compound 3; then compounds 1 and 2 (each within the scatter of the next).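

Placing 4-fluoro-3-methylphenyl on the amide-type nitrogen gives an 8.9-fold lower number from compound 2 to compound 3 (0.95 log units; beyond the scatter) and a 5.3-fold lower number from compound 1 to compound 3 (0.72 log units; beyond the scatter) in this assay; the only earlier step at this position stayed within the scatter. The aryl group on this nitrogen can therefore shift the number beyond the scatter, and 3-ethylphenyl and 3-fluorophenyl do not show the full span of this position. No evidence here bears on the reason for this shift. Going by these compounds, whether the methyl or the fluoro of 4-fluoro-3-methylphenyl carries the step stays open. So does the effect of a chloro or methoxy group on that ring.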